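Dithiocarbamate benzamides: arylpiperazine in place of pyridylmethylpiperazine

The source may hold more compounds than are shown below. What is called first, only, known or untested is meant among the compounds shown, and "the series" means these compounds.

Compound 3 `Nc1ccccc1NC(=O)c1ccc(CSC(=S)N2CCN(Cc3ccncc3)CC2)cc1` gives 59.5% in a functional assay on HeLa cells (Homo sapiens) for antiproliferative activity, read by CCK-8 assay, with a stated time of 72 h, tested at 2 uM (a lower number here means a weaker effect, a higher number a stronger effect of the compound at the concentration tested), the second highest of the three numbers measured. Its nearest neighbour is compound 2 `Nc1ccccc1NC(=O)c1ccc(CSC(=S)N2CCN(c3cccnc3)CC2)cc1`, which in this assay gives 66.2%; the gap a number 6.7 percentage points lower from compound 2 to compound 3 (within the scatter) lies within the scatter. Furthest away is compound 1 `Nc1ccccc1NC(=O)c1ccc(CSC(=S)N2CCN(Cc3ccccn3)CC2)cc1`, which in this assay gives 14.2%.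

Compound 4 `Cc1ccc(N2CCN(C(=S)SCc3ccc(C(=O)Nc4ccccc4N)cc3)CC2)cc1` is not yet measured. Against compound 3 the change is 4-methylphenyl in place of (pyridin-4-yl)methyl on an amine nitrogen in a ring.

Which steps bear on it: both large measured steps start from compound 1. The step of a number 52 percentage points higher from compound 1 to compound 2 (beyond the scatter) removes the methylene between the ring nitrogen and the pyridine while moving the ring nitrogen of the pyridine; the step of a number 45.3 percentage points higher from compound 1 to compound 3 (beyond the scatter) keeps the methylene and moves only the pyridine nitrogen. The step of a number 6.7 percentage points lower from compound 2 to compound 3 (within the scatter) shows that a six-membered aromatic ring attached directly to the piperazine nitrogen and one attached through a methylene give numbers within the scatter of each other. For the measured compounds named here, no measured step exchanges a pyridine for a carbon-only ring, so the loss of the hydrogen-bond acceptor in compound 4 has no precedent here.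

On this basis compound 4 is expected to stay near compound 3, with the step of a number 1.5 percentage points lower from compound 3 to compound 4 (within the scatter) estimated to fall within the scatter. The estimate for compound 4 is 58%, with a range from 32% to 80%.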

Compound 4, a percentage reported as inhibition, at one concentration (the size of the read-out at that concentration, not a potency): 25.3%
For compound 4 the middle estimate is 32.7 percentage points above the measured one; the measured number lies below the stated range.
By their numbers in this assay, from the lowest: compound 1; then compound 4; then compounds 3 and 2 (each within the scatter of the next).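

At the amine nitrogen in the ring, a six-membered aromatic ring does not by itself hold the level of the pyridine compounds: in this assay the exchange of (pyridin-4-yl)methyl for 4-methylphenyl is a number 34.2 percentage points lower from compound 3 to compound 4 (beyond the scatter) and the exchange of pyridin-3-yl for 4-methylphenyl is a number 40.9 percentage points lower from compound 2 to compound 4 (beyond the scatter), so the earlier agreement between compound 2 and compound 3 does not extend to this carbon-only ring. A pyridine ring nitrogen is not sufficient either, since compound 1 carries one and the step to the carbon-only ring is still upward, a number 11.1 percentage points higher from compound 1 to compound 4 (beyond the scatter), which makes compound 1 the exception to any simple rule that a pyridine ring gives the higher number. No measurement at hand accounts for these differences.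

As far as these compounds go, the exchange from compound 3 alters the ring nitrogen, the methyl group and the methylene at once, so the share of each stays open. Plain phenyl and benzyl on the same nitrogen would separate these three changes, and pyridin-2-yl attached directly would show whether the low number of compound 1 follows the position of the ring nitrogen.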